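Shortening the Chain: From Compound 2 to Compound 3

This account rests on a few compounds, and the source may have more. Where it says the series, first, only, none or still open, it means among the compounds named here.

Compound 1 `CCC/C(CC)=N\Nc1nc(-c2cccc([N+](=O)[O-])c2)cs1`: 4860 nM
Compound 2 `CCCCC/C(CC)=N\Nc1nc(-c2cccc([N+](=O)[O-])c2)cs1`: 7150 nM

For the measured compounds named here, in an assay on isolated protein for inhibition of Amine oxidase [flavin-containing] A (Homo sapiens), read by fluorescence, with a stated time of 20 min (on this read-out higher numbers stand for weaker inhibition and lower numbers for stronger inhibition), compound 2 gives 7150 nM, the higher of the two numbers so far, with compound 1 nearest at 4860 nM. Going by the values given here, the only measured step, a 1.5-fold higher number from compound 1 to compound 2 (0.17 log units; within the scatter), stayed within the scatter. Compound 3 `CCCC/C(CC)=N\Nc1nc(-c2cccc([N+](=O)[O-])c2)cs1` differs from compound 2 by hydrogen in place of methyl on a saturated chain carbon, four bonds along the chain from a carbon with a double bond to nitrogen, a change to the same saturated chain that the measured step touched. No step beyond the scatter is expected for compound 3 because a 1.5-fold higher number from compound 1 to compound 2 (0.17 log units; within the scatter) stayed within the scatter. Compound 3 is therefore estimated at 5900 nM, with a range from 2900 nM to 12000 nM. That estimate means a 1.2-fold lower number from compound 2 to compound 3 (0.08 log units; within the scatter).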

Compound 3, half-maximal inhibitory concentration: 6030 nM
Compound 3: the middle estimate sits 1.0-fold (0.01 log units) below what was measured, and the stated range covers the measured number.
By their numbers in this assay, from the lowest: compounds 1, 3 and 2 (each within the scatter of the next).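

In this assay, hydrogen in place of methyl at this chain carbon gives a 1.2-fold lower number from compound 2 to compound 3 (0.07 log units; within the scatter), and methyl in place of hydrogen three bonds along the chain gives a 1.2-fold higher number from compound 1 to compound 3 (0.09 log units; within the scatter). All three chain lengths therefore lie within the scatter of one another, so the middle chain stands out from neither neighbour. Nothing available explains these small steps.

The compounds shown leave open whether a much longer chain, or an amine or a carboxylic acid on this chain, would give a step beyond the scatter.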